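The source may hold more compounds than are shown below. What is called first, only, known or untested is meant among the compounds shown, and "the series" means these compounds.

In an in vivo ADME assay on the whole organism (Canis lupus familiaris) for pharmacokinetics (on this read-out higher numbers stand for higher oral bioavailability and lower numbers for lower oral bioavailability), compound 1 `O=C(O)CC(NC(=O)CCCCc1ccc2c(n1)NCCC2)c1cncnc1` gives 10% and compound 2 `O=C(O)C[C@H](CCCCCCc1ccc2c(n1)NCCC2)c1cnc2ccccc2c1` gives 65%. Compound 3 `O=C(O)C[C@H](CCCCCCc1ccc2c(n1)NCCC2)c1ccc2c(c1)OCC2` gives > 99%, which is a limit of the assay and not a number. Going by the values given here, it is the only one of the three compounds to reach that limit.

Compound 4 `COc1ncc([C@@H](CCCCCCc2ccc3c(n2)NCCC3)CC(=O)O)cn1` keeps the chain and the core of compound 3 but changes the group on a saturated chain carbon bound to two saturated chain carbons: a group of 8 heavy atoms (5 carbon, 2 nitrogen, 1 oxygen; one six-membered aromatic ring with 2 hetero atoms) in place of a group of 9 heavy atoms (8 carbon, 1 oxygen; one five-membered non-aromatic ring with 1 hetero atom, one six-membered aromatic ring of carbon only), on a saturated chain carbon bound to two saturated chain carbons. The 2-methoxypyrimidin-5-yl group that enters has not been measured on this chain. Among the compounds with values here, the one measured step at this place is a number at least 34 percentage points higher from compound 2 to compound 3 (beyond the scatter). That step shows that exchanging this group alone can move this assay by a large amount, though it does not show how this particular exchange will act. Compound 1 also has a six-membered aromatic ring with 2 hetero atoms, but it differs in other places too, so its 10% is only a loose guide.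

A large fall is therefore expected, with compound 4 landing nearer to compound 2 at 65% than to compound 3. The expected change is a number at least 44 percentage points lower from compound 3 to compound 4 (beyond the scatter). The estimate for compound 4 is 55%, with an expected range from 25% to 90%.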

Compound 4, oral bioavailability: 100%
Beside the measured number, compound 4's estimate is 45 percentage points below it, outside the stated range (above it).
By their numbers in this assay, from the lowest: compound 1; then compound 2; then compound 4.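

In this assay, with the chain and the core held fixed, putting 2-methoxypyrimidin-5-yl in place of quinolin-3-yl on a saturated chain carbon bound to two saturated chain carbons gives a number 35 percentage points higher from compound 2 to compound 4 (beyond the scatter), so a group with a single six-membered aromatic ring with 2 hetero atoms also stands well clear of the quinolin-3-yl compound, as the group of compound 3 does. At this place, then, a high value does not depend on the fused pair of rings that compound 3 carries, and neither of the two groups that beat quinolin-3-yl shares the ring type of the other. Compound 3 gives > 99%, which is a limit of the assay and not a number, and the step that leads from it to compound 4 cannot be read because of that limit: the limit of > 99% in this assay, at which 1 of the 4 values shown sits.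

The compounds shown leave open how much of the gain belongs to the methoxy group, since no pyrimidin-5-yl carrying an amine or only hydrogen in its place stands beside compound 4. They also leave open whether the value would hold on a shorter chain or on one with an amide, as compound 1 differs from compound 4 in more than one place.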